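This account rests on a few compounds, and the source may have more. Where it says the series, first, only, none or still open, it means among the compounds named here.

Compound 2, `CCCc1cnc(N2CCC(C3Cc4cc(C5=CCN(S(=O)(=O)CCCO)CC5)cc(F)c4O3)CC2)nc1`, is the compound from which this step starts. In a functional assay on HEK293 cells for agonist activity at Glucose-dependent insulinotropic receptor (Homo sapiens), read by cAMP accumulation, with a stated time of 60 min (on this read-out lower numbers stand for an effect already at smaller amounts and higher numbers for an effect only at larger amounts of compound), compound 2 gives 122 nM, the numerically higher of the two numbers measured, while compound 1, `CCCc1cnc(N2CCC(C3Cc4cc(C5=CCN(S(=O)(=O)CCC)CC5)cc(F)c4O3)CC2)nc1`, gives 62 nM in this assay; the gap, a 2.0-fold higher number from compound 1 to compound 2 (0.29 log units; within the scatter), lies within the scatter, so the two cannot be told apart. Compound 3, `CCCc1cnc(N2CCC(C3Cc4cc(C5=CCN(S(=O)(=O)CCCCO)CC5)cc(F)c4O3)CC2)nc1`, differs from compound 2 by hydroxymethyl in place of hydroxy on a saturated chain carbon, three bonds along the chain from a sulfonyl sulfur. Going by the values given here, the only measured step that touches the same chain carbon is a 2.0-fold higher number from compound 1 to compound 2 (0.29 log units; within the scatter), and it stayed within the scatter. Nothing measured shows how the chain's length matters, so no effect beyond the scatter is expected in this assay, and compound 3 is estimated to shift from compound 2 by a 1.0-fold lower number from compound 2 to compound 3 (0.01 log units; within the scatter). Compound 3 is therefore expected to give about 120 nM in this assay, with a range from 55 nM to 260 nM.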

Compound 3, half-maximal effective concentration: 60 nM
Compound 3: the middle estimate sits 2.0-fold (0.30 log units) above what was measured; low and high end bracket the measured number.
By their numbers in this assay, from the lowest: compounds 3, 1 and 2 (each within the scatter of the next, the first and the last beyond it).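

In this assay, going by these compounds alone, hydroxymethyl in place of hydroxy on a saturated chain carbon, three bonds along the chain from a sulfonyl sulfur, gives a 2.0-fold lower number from compound 2 to compound 3 (0.31 log units; beyond the scatter) and is the only step at this carbon that passes beyond the scatter, though modestly. Hydroxymethyl in place of hydrogen at the same carbon gives a 1.0-fold lower number from compound 1 to compound 3 (0.01 log units; within the scatter) and so cannot be told apart from hydrogen, which means that the 4-hydroxybutyl chain of compound 3 shows no readable difference from the chain of compound 1. Nothing measured on these compounds bears on why the number moves between the 3-hydroxypropyl and 4-hydroxybutyl chains.

From the compounds shown here alone, whether a longer chain would move the number further remains open. So does the outcome of placing an amine or a carboxylic acid in place of the hydroxy of the 4-hydroxybutyl chain.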